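The source may hold more compounds than are shown below. What is called first, only, known or untested is meant among the compounds shown, and "the series" means these compounds.

Measured so far:
- compound 1, `CS(=O)(=O)c1cnc(C(=O)CCc2ccc(-c3ccccc3)cc2)o1`: 1.2 nM
- compound 2, `O=C(O)c1cccc(-c2cnc(C(O)CCc3ccc(-c4ccccc4)cc3)o2)n1`: 1100 nM

In an assay for inhibition of Fatty-acid amide hydrolase 1 (Rattus norvegicus) (a higher number here means a weaker inhibitor, a lower number a stronger inhibitor), compound 1 gives 1.2 nM, the lower of the two numbers shown; compound 2 gives 1100 nM, a difference well beyond the scatter. Compound 3, `CN(C)C(=O)c1cnc(C(=O)CCc2ccc(-c3ccccc3)cc2)o1`, keeps the ketone-linked chain of compound 1 and changes only the group on the five-membered ring: dimethylcarbamoyl in place of methylsulfonyl on an aromatic carbon. Going by the values given here, no step between measured compounds covers this change. The expected step from compound 1 to compound 3 is a 4.2-fold higher number from compound 1 to compound 3 (0.62 log units; beyond the scatter), a modest weakening, since the ketone that compound 1 carries is retained. Compound 3 is estimated at 5 nM, within 1 nM to 30 nM.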

Compound 3, inhibition constant: 3 nM
The estimate for compound 3 lay 1.7-fold (0.22 log units) above the measured number; the range from low to high includes it.
By their numbers in this assay, from the lowest: compound 1; then compound 3; then compound 2.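

In this assay, dimethylcarbamoyl in place of methylsulfonyl on the aromatic carbon next to the ring oxygen gives a 2.5-fold higher number from compound 1 to compound 3 (0.40 log units; beyond the scatter), a modest step. This position therefore accepts two different carbonyl- and sulfur-free-of-charge neutral groups, with compound 3 still at 3 nM. Nothing measured alongside these numbers accounts for the size of the step.

Going by these compounds, whether an amine, a carboxylic acid or a nitrile at this position would keep such numbers remains open. On these data alone, compound 2 differs from compound 1 in more than one place, so the contribution of the ketone also remains open.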